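The source may hold more compounds than are shown below. What is called first, only, known or untested is meant among the compounds shown, and "the series" means these compounds.

Compound 1, `CO[C@H]1C(=O)N2[C@@H](C(=O)OCc3ccc(C(=O)O)cc3)C(C)(C)S(=O)(=O)[C@H]12`: in a physicochemical assay (a higher number here means that the compound lasts longer, a lower number that the compound disappears faster), compound 1 gives < 1 h, which is a limit of the assay and not a number.
Compound 2, `CC1(C)[C@H](C(=O)OCc2ccc(C(=O)O)cc2)N2C(=O)[C@@H](NC(=O)C(F)(F)F)[C@H]2S1(=O)=O`: in this assay compound 2 gives 1.1 h.

For the measured compounds named here, compound 2 therefore stands as the only one of the two with a number; the other entry is the limit of < 1 h in this assay, at which 1 of the 2 values shown sits, so there is no measured step to compare it against. Compound 3, `CC1(C)[C@H](C(=O)OCc2ccc(C(=O)O)cc2)N2C(=O)[C@H](NC(=O)C(F)(F)F)[C@H]2S1(=O)=O`, is built from the same pieces as compound 2: the two compounds have the same atoms and bonds and differ only in configuration as drawn: 1 of 3 stereo elements differ; a stereocentre at a saturated ring carbon is drawn R in compound 2 and S in compound 3. In words, the two compounds have the same atoms and bonds and differ only in configuration as drawn; one of three stereo elements differs, a stereocentre at a saturated ring carbon being drawn R in compound 2 and S in compound 3. Going by the values given here, no step between measured compounds is available to say how large a change of configuration alone tends to be in this assay, so the expectation rests on compound 2 and its value alone. The step that this estimate means, no change at the digits printed from compound 2 to compound 3 (within the scatter), is expected to stay within the usual scatter, in no particular direction. Compound 3 is thus expected to give 1.1 h, with a range from 0.5 h to 2.5 h.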

Compound 3, half-life: 1.1 h
The estimate for compound 3 equals the measured number at the digits printed; measured number inside the range.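

In this assay, for the compounds shown here, this pair gives the first measured step at this position: no change at the digits printed from compound 2 to compound 3 (within the scatter). For the ((trifluoromethyl)carbonyl)amino group on this saturated ring carbon, the R and S forms therefore stay within the scatter of each other, and the comparison can be read directly because nothing else separates the two compounds: the fact that compounds 2 and 3 differ only in the configuration as drawn. The step of an at least 1.1-fold higher number from compound 1 to compound 3 (0.04 log units; that floor lies within the scatter) is only a floor and does not show how methoxy and ((trifluoromethyl)carbonyl)amino rank on that carbon, because one end of it is a limit of the assay and not a number: the limit of < 1 h in this assay, at which 1 of the 3 values shown sits.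

The compounds shown leave open whether configuration at this carbon is equally without consequence when another group sits there, such as methoxy, a free amine or a carboxylic acid. They also leave open whether a longer chain in place of trifluoromethyl in the amide, or a different ester in place of the one shared by all three compounds, would give a half-life beyond the scatter in this assay.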